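A few compounds are considered here, and "the series" means these few. Any claim that something is new, unique, unknown or untested is made for them only; others in the source may bear on it.

Working notes on the series. In a functional assay on A549 cells (Homo sapiens) for cytotoxicity, read by MTT assay, with a stated time of 48 h (a higher number here means that more compound is needed for the effect, a lower number that less compound is needed), compound 1 `Cc1c(O)c(=O)ccn1CC(=O)N/N=C1\C(=O)N(CC(=O)Nc2ccc(Br)cc2)c2ccccc21` gives 29300 nM. Compound 2 `Cc1c(O)c(=O)ccn1CC(=O)N/N=C1\C(=O)N(CC(=O)Nc2ccc(Cl)cc2)c2ccccc21` gives 28300 nM in this assay, and the pair shows a 1.0-fold lower number from compound 1 to compound 2 (0.02 log units; within the scatter). Compound 3 `CC(=O)Nc1ccc(NC(=O)CN2C(=O)/C(=N\NC(=O)Cn3ccc(=O)c(O)c3C)c3ccccc32)cc1` reaches only > 100000 nM in this assay, which is a limit of the assay and not a number. Compound 3 therefore stands at the weak end of the three: an at least 3.4-fold higher number from compound 1 to compound 3 (0.53 log units; beyond the scatter) and an at least 3.5-fold higher number from compound 2 to compound 3 (0.54 log units; beyond the scatter), with the limit noted as the limit of > 100000 nM in this assay, at which 1 of the 3 values shown sits.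

Compound 4 `Cc1c(O)c(=O)ccn1CC(=O)N/N=C1\C(=O)N(CC(=O)Nc2cccc(Cl)c2)c2ccccc21` differs from compound 3 in one place: 3-chlorophenyl in place of 4-acetamidophenyl on an amide-type nitrogen. The measured steps that bear on this run the other way, an at least 3.5-fold higher number from compound 2 to compound 3 (0.54 log units; beyond the scatter) and an at least 3.4-fold higher number from compound 1 to compound 3 (0.53 log units; beyond the scatter), both moving from a halogen to acetamido and both giving a higher number. Reversing that move should give a lower number, but the measured halogen compounds carry their chloro or bromo at a different place on the ring, and no measured pair covers that shift. The expectation is a return toward the level of compound 2 at 28300 nM. For compound 4 the estimate is 35000 nM, with a range from 15000 nM to 100000 nM. This estimate means a step of an at least 2.8-fold lower number from compound 3 to compound 4 (0.45 log units; beyond the scatter).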

Compound 4, half-maximal effective concentration: 28000 nM
Compound 4: the middle estimate sits 1.3-fold (0.10 log units) above what was measured, and the stated range covers the measured number.
By their numbers in this assay, from the lowest: compounds 4, 2 and 1 (each within the scatter of the next). At a limit, above all of these: compound 3.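

Shifting the chlorine on the aryl group, from 4-chlorophenyl to 3-chlorophenyl, leaves the reading in this assay unchanged within the scatter, with a 1.0-fold lower number from compound 2 to compound 4 (0.00 log units; within the scatter), and this is the first measured view of placement on this ring. The exchange of 4-bromophenyl for 3-chlorophenyl agrees, with a 1.0-fold lower number from compound 1 to compound 4 (0.02 log units; within the scatter), so among the three halogen compounds neither the halogen nor its placement separates the values. Replacing 4-acetamidophenyl with 3-chlorophenyl gives an at least 3.5-fold lower number from compound 3 to compound 4 (0.55 log units; beyond the scatter), which shows that the separation of the acetamido compound from the halogen compounds also holds for this new placement, but this step has only a bound, since compound 3 stands at a limit of the assay and not at a number: the limit of > 100000 nM in this assay, at which 1 of the 4 values shown sits.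

On these data alone, what remains open is whether the acetamido group would read the same at the other ring placement, as chloro does here. Also open, as far as these compounds go, is where an amine, a carboxylic acid or a methoxy group on this phenyl ring would fall relative to the halogen compounds and compound 3.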